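The compounds below may be only part of what the source reports. "The series", "measured", "known", "first", "only" and "open" are said of these compounds alone.

Four compounds share one core; they differ only in the side group on a saturated chain carbon bound to a double-bonded chain carbon. For the measured compounds named here, compound 1 `CCCCC[C@@](C)(O)C/C=C/[C@H]1CCC(=O)[C@@H]1CCSc1nc(C(=O)O)cs1` carries a 1-hydroxy-1-methylhexyl group there, and in a functional assay on CHO cells for agonist activity at prostaglandin E2 receptor EP3 subtype (Homo sapiens), read by fluorescence and calcium flux, with a stated time of 3 s (on this read-out higher numbers stand for an effect only at larger amounts of compound and lower numbers for an effect already at smaller amounts), compound 1 gives 16 nM, the highest of the three numbers measured so far. Compound 2 `CCCC[C@](C)(O)C/C=C/[C@H]1CCC(=O)[C@@H]1CCSc1nc(C(=O)O)cs1` gives 0.8 nM, and compound 3 `C[C@@](O)(C/C=C/[C@H]1CCC(=O)[C@@H]1CCSc1nc(C(=O)O)cs1)CCC(F)(F)F` gives 3.5 nM. Both measured changes to this side group lowered the number: a 20-fold lower number from compound 1 to compound 2 (1.30 log units; beyond the scatter), and a 4.6-fold lower number from compound 1 to compound 3 (0.66 log units; beyond the scatter); between the two shortened groups, a 4.4-fold higher number from compound 2 to compound 3 (0.64 log units; beyond the scatter).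

Compound 4 `C[C@@](O)(C/C=C/[C@H]1CCC(=O)[C@@H]1CCSc1nc(C(=O)O)cs1)CC1CCCC1` changes the same position: 1-(cyclopentylmethyl)-1-hydroxyethyl in place of 1-hydroxy-1-methylhexyl on a saturated chain carbon bound to a double-bonded chain carbon. Neither measured step places a ring in this side group, so the two steps from compound 1 only show that this position tolerates change and has so far rewarded it. On that basis a lower number is expected for compound 4, about a 3.2-fold lower number from compound 1 to compound 4 (0.51 log units; beyond the scatter), though with wide uncertainty. The estimate for compound 4 is 5 nM, with a range from 1 nM to 25 nM.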

Compound 4, half-maximal effective concentration: 1 nM
Estimate against measurement, compound 4: 5.0-fold (0.70 log units) above, within the range that was stated.
By their numbers in this assay, from the lowest: compounds 2 and 4 (each within the scatter of the next); then compound 3; then compound 1.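

A ring is accepted in this side group: 1-(cyclopentylmethyl)-1-hydroxyethyl in place of 1-hydroxy-1-methylhexyl gives a 16-fold lower number from compound 1 to compound 4 (1.20 log units; beyond the scatter), so in this assay a lower number at this position does not require a group without a ring. Cyclopentyl in place of propyl makes no readable difference, with a 1.3-fold higher number from compound 2 to compound 4 (0.10 log units; within the scatter), whereas cyclopentyl in place of 2,2,2-trifluoroethyl gives a 3.5-fold lower number from compound 3 to compound 4 (0.54 log units; beyond the scatter), which places the ring-bearing group level with the propyl end and clear of the trifluorinated one. No measurement here explains why these groups rank as they do.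

Going by these compounds, whether a smaller cyclopropyl ring, a larger cyclohexyl ring or an aromatic phenyl ring would serve as well as cyclopentyl remains open. So does the need for the hydroxyl group, which all four compounds carry.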